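The source may report more compounds than this note shows. Statements on the series, on what has been measured and on what is new or still open speak of the compounds shown alone.

Measured in a functional assay on MCF7 cells (Homo sapiens) for inhibition, read by MTT assay, with a stated time of 48 h; on this read-out lower numbers stand for stronger inhibition and higher numbers for weaker inhibition:
- compound 1 `COc1cc(/C=C/C(=O)Nc2ccccc2N)ccc1OCC(=O)Nc1cccc(F)c1`: > 100000 nM (a limit of the assay)
- compound 2 `COc1cc(/C=C/C(=O)NO)ccc1OCC(=O)Nc1cccc(F)c1`: 39500 nM
- compound 3 `COc1cc(/C=C/C(=O)Nc2ccccc2N)ccc1OCC(=O)Nc1cc(C(F)(F)F)cc(C(F)(F)F)c1`: 43100 nM

Compound 1 gives > 100000 nM, which is a limit and not a number; this is the limit of > 100000 nM in this assay, at which 1 of the 3 values shown sits. Compound 4 `COc1ccc(NC(=O)COc2ccc(/C=C/C(=O)Nc3ccccc3N)cc2OC)cc1` keeps the core of compound 1 and changes one group: 4-methoxyphenyl in place of 3-fluorophenyl on an amide-type nitrogen. In words, this is 4-methoxyphenyl in place of 3-fluorophenyl on an amide-type nitrogen.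

For the measured compounds named here, the only measured step, an at least 2.5-fold lower number from compound 1 to compound 2 (0.40 log units; beyond the scatter), replaces a different group, so it bears on this change only weakly. Compound 3 gives 43100 nM, which shows that a compound sharing the 2-aminophenyl amide can still return a number in this assay. Nothing measured points to a large gain, so only a small step is expected in this assay, not clearly beyond the scatter and with its direction open. Another reading at the limit would be no surprise. The estimated change is a number no higher from compound 1 to compound 4 (the limit leaves the size open). For compound 4 the expected value is 100000 nM, with an estimated range from 40000 nM to 250000 nM.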

Compound 4, half-maximal inhibitory concentration: > 100000 nM
Compound 4 ended at the assay's limit; the forecaster's own chance of this, stated with the estimate: 55%; the middle value sits exactly at the limit.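

From the compounds shown here alone, compound 1 and compound 4 both stand at a limit of the assay and not at a number, so no step can be read between them: the limit of > 100000 nM in this assay, at which 2 of the 4 values shown sit. Whether 4-methoxyphenyl in place of 3-fluorophenyl on an amide-type nitrogen changes the result in this assay at all remains open.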